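Replacing hydroxymethyl in a series held at the limit

The source may hold more compounds than are shown below. What is called first, only, known or untested is meant among the compounds shown, and "the series" means these compounds.

compound 1 `O=C(O)c1ccc(-c2nn(Cc3ccccc3)c3ccccc23)cc1`: > 10000 nM (a limit)
compound 2 `CCNC(=O)c1ccc(-c2nn(Cc3ccccc3)c3ccccc23)cc1`: > 10000 nM (a limit)
compound 3 `OCc1ccc(-c2nn(Cc3ccccc3)c3ccccc23)cc1`: > 10000 nM (a limit)

All three entries come from a functional assay on cells (Platelet, Homo sapiens) for inhibition (a lower number here means a stronger inhibitor, a higher number a weaker inhibitor), and none of them is a number. For the measured compounds named here, the series so far shows (the limit of > 10000 nM in this assay, at which 3 of the 3 values shown sit). Compound 3 therefore has no measured potency to compare against, only its limit.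

The open change leads to compound 4 `CO/N=C\c1ccc(-c2nn(Cc3ccccc3)c3ccccc23)cc1` and reads: a group of 4 heavy atoms (2 carbon, 1 nitrogen, 1 oxygen; no ring) in place of a group of 2 heavy atoms (1 carbon, 1 oxygen; no ring), on an aromatic carbon. The entering group has a double bond outside aromatic rings and, like the group that leaves, no net charge. None of the three measured compounds carries a group of this kind.

Going by the values given here, three measured steps bear on this place in the structure: a step that the two limits leave unreadable from compound 1 to compound 3, a step that the two limits leave unreadable from compound 2 to compound 3 and a step that the two limits leave unreadable from compound 1 to compound 2. None of them has a readable size, so no direction can be carried over to the new group. Compound 3 at > 10000 nM, itself a limit, offers no number to step from, so no step beyond the scatter can be expected on these data.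

The step expected is a step that the limit leaves unreadable from compound 3 to compound 4. A further report at the limit in this assay is expected to be the likeliest outcome. For compound 4 the estimate is 15000 nM, with an expected range from 4000 nM to 50000 nM.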

Compound 4, half-maximal inhibitory concentration: > 10000 nM
Compound 4: only a limit was reported; the forecaster's own chance of this, stated with the estimate: 70%; the middle value is on the limit's open side.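

In this assay, for the compounds shown here, compound 4 gives > 10000 nM as a limit and not a number, so no step from compound 1, compound 2 or compound 3 to compound 4 can be read. The compounds shown leave open whether any group at this place on the shared core gives a measured potency, since the series holds only one reading: the limit of > 10000 nM in this assay, at which 4 of the 4 values shown sit.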